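Swapping the amide-bound ring in a weakly active analogue

The compounds below may be only part of what the source reports. "The series", "measured", "known", "first", "only" and "open" are said of these compounds alone.

Of the compounds shown here, three built on one shared core have been tested in a functional assay on A549 cells (Homo sapiens) for inhibition, read by MTT assay, with a stated time of 24 h; a lower number here means a stronger inhibitor, a higher number a weaker inhibitor. Compound 1, `CCOC(=O)C1=Cc2ccccc2OC1(OCc1cn(-c2ccc(F)cc2)nn1)C(F)(F)F`, carries a 4-fluorophenyl group on an aromatic nitrogen of the core, and in this assay compound 1 gives 7300 nM. Compound 2, `CCOC(=O)C1=Cc2ccccc2OC1(OCc1cn(-c2ccc(C)cc2)nn1)C(F)(F)F`, has a methyl in place of that fluoro, and in this assay compound 2 gives 19700 nM, which is a 2.7-fold higher number from compound 1 to compound 2 (0.43 log units; beyond the scatter). Compound 3, `CCOC(=O)C1=Cc2ccccc2OC1(OCc1cn(CC(=O)Nc2cccc(F)c2)nn1)C(F)(F)F`, instead carries a ((3-fluorophenyl)carbamoyl)methyl group on the aromatic nitrogen. For compound 3, this assay reports only a limit, > 150000 nM. Compound 3 therefore stands at the weak end of the three, with an at least 20-fold higher number from compound 1 to compound 3 (1.31 log units; beyond the scatter) and an at least 7.6-fold higher number from compound 2 to compound 3 (0.88 log units; beyond the scatter), its position being (the limit of > 150000 nM in this assay, at which 1 of the 3 values shown sits).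

Compound 4, `CCOC(=O)C1=Cc2ccccc2OC1(OCc1cn(CC(=O)Nc2ccccc2Br)nn1)C(F)(F)F`, is compound 3 with one change: 2-bromophenyl in place of 3-fluorophenyl on an amide-type nitrogen. Among the compounds with values here, no measured step touches this amide-bound ring. Within the data shown here, the only swap of a ring substituent that has been measured, a 2.7-fold higher number from compound 1 to compound 2 (0.43 log units; beyond the scatter), was modest, and a change of that size starting from compound 3 would not be expected to bring the number back under the limit. Compound 4 is therefore expected to remain near the limit, with an estimate of 200000 nM, spanning 80000 nM to 600000 nM, meaning an expected step that the limit leaves unreadable from compound 3 to compound 4.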

Compound 4, half-maximal inhibitory concentration: > 150000 nM
Compound 4: only a limit was reported; the forecaster's own chance of this, stated with the estimate: 75%; the middle value does not contradict the limit.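

In this assay, replacing 3-fluorophenyl with 2-bromophenyl on the amide-type nitrogen gives a second compound that reports only a limit, so the step between compound 3 and compound 4 cannot be read and neither ring can be ranked over the other. What is new is that the weak result is no longer tied to a single amide-bound ring, and the gap to the compounds with a ring directly on the aromatic nitrogen remains wide, with an at least 20-fold higher number from compound 1 to compound 4 (1.31 log units; beyond the scatter) and an at least 7.6-fold higher number from compound 2 to compound 4 (0.88 log units; beyond the scatter). The readout at this position therefore stops at the same limit for both rings tested: the limit of > 150000 nM in this assay, at which 2 of the 4 values shown sit.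

The compounds shown leave open whether any group on the amide-type nitrogen can bring the number back under this limit, for example a ring carrying a carboxylic acid or an amine, or a cyclohexyl group in place of the ring. They also do not separate the effect of the carbamoyl link from that of the ring it carries, a question that a benzyl group on the aromatic nitrogen could help address.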